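Solubility of Compound 3 and an Untested Analogue

The source may report more compounds than this note shows. Statements on the series, on what has been measured and on what is new or still open speak of the compounds shown alone.

Measured compounds:
- compound 1, `COc1cccc(CN2C(=O)CN(C(=O)c3cc4cc(OC)ccc4o3)C[C@@H]2CCc2ccccc2)c1`: 4900 nM
- compound 2, `COc1cccc(CN2C(=O)CN(C(=O)c3cc4cc(OC)ccc4[nH]3)C[C@@H]2COCc2ccccc2)c1`: 11700 nM
- compound 3, `COc1ccc2[nH]c(C(=O)N3CC(=O)N(Cc4ccccc4)[C@@H](N4[C@H](C)CCC[C@@H]4C)C3)cc2c1`: 100000 nM

In a physicochemical assay for solubility, read by spectrophotometry, in phosphate buffer, with a stated time of 2 h, at pH 7.4 (on this read-out higher numbers stand for higher solubility and lower numbers for lower solubility), compound 3 gives 100000 nM, the highest of the three numbers. Its nearest neighbour is compound 2, which gives 11700 nM, and the furthest is compound 1, which gives 4900 nM; both gaps lie beyond the scatter, so compound 3 is the most soluble of the three.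

Compound 4, `COc1ccc2[nH]c(C(=O)N3CC(=O)N(Cc4ccccc4)[C@@H](CN4CCCc5ccccc54)C3)cc2c1`, has not yet been measured. It differs from compound 3 in one place: (1,2,3,4-tetrahydroquinolin-1-yl)methyl in place of 2,6-dimethylpiperidin-1-yl on a saturated ring carbon. Within the data shown here, no step between two measured compounds covers this change, so there is no directly comparable precedent in the set. The group that enters is larger than the one that leaves and carries an additional aromatic ring. On that basis the expectation for compound 4 is a number lower than that of compound 3, by a step estimated as a 4.0-fold lower number from compound 3 to compound 4 (0.60 log units; beyond the scatter) in this assay. Compound 4 is expected to give about 25000 nM, within a range from 8000 nM to 80000 nM.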

Compound 4, solubility: 8500 nM
Estimate against measurement, compound 4: 2.9-fold (0.47 log units) above; measured number inside the range.
By their numbers in this assay, from the lowest: compounds 1, 4 and 2 (each within the scatter of the next, the first and the last beyond it); then compound 3.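

In this assay, among these compounds, putting (1,2,3,4-tetrahydroquinolin-1-yl)methyl in place of 2,6-dimethylpiperidin-1-yl on a saturated ring carbon gives a 12-fold lower number from compound 3 to compound 4 (1.07 log units; beyond the scatter) and provides the first step in this set between compounds that differ in one place. It shows that a change at this position alone, with the rest of compound 3 held constant, can move the number by a large step. The entering group differs in several ways at once, with more heavy atoms, an added six-membered aromatic ring and no defined stereocentres, and nothing at hand says which of these matters.

The compounds shown leave open whether the step follows the added aromatic ring or the methyl link. A piperidin-1-ylmethyl group or a morpholin-4-yl group at this position would help to separate these differences.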